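This account rests on a few compounds, and the source may have more. Where it says the series, first, only, none or still open, it means among the compounds named here.

In an ADME assay on the whole organism for metabolic stability, with Rattus norvegicus as the target (a lower number here means that the compound disappears faster, a higher number that the compound lasts longer), compound 1 `O=S(=O)(c1ccc(F)cc1)c1cc(F)c(O)c2ncccc12` gives 4.5 h, compound 2 `Cc1ccc(S(=O)(=O)c2cc(F)c(O)c3ncccc23)cc1` gives 0.26 h and compound 3 `O=S(=O)(c1cc(F)c(O)c2ncccc12)C1CCCC1` gives 7.7 h. Compound 3 stands at the upper end of these numbers, a place it shares within the scatter: a 1.7-fold higher number from compound 1 to compound 3 (0.23 log units; within the scatter). The gap to the low end is wide: a 30-fold higher number from compound 2 to compound 3 (1.47 log units; beyond the scatter). Compound 4 `O=S(=O)(c1cc(F)c(O)c2ncccc12)N1CCCC1` carries pyrrolidin-1-yl in place of cyclopentyl on a sulfonyl sulfur, pyrrolidin-1-yl in place of cyclopentyl on a sulfonyl sulfur. Two measured steps change the same place: a 1.7-fold higher number from compound 1 to compound 3 (0.23 log units; within the scatter) stays small, while a 30-fold higher number from compound 2 to compound 3 (1.47 log units; beyond the scatter) is large. The other large step, a 17-fold lower number from compound 1 to compound 2 (1.24 log units; beyond the scatter), concerns a methyl that compound 4 lacks. For the measured compounds named here, no measured compound carries pyrrolidin-1-yl, so the range stays wide. In this assay, the expected step is a 1.5-fold lower number from compound 3 to compound 4 (0.19 log units; within the scatter), nothing beyond the scatter. For compound 4 the estimated half-life is 5 h, with an expected range of 1.5 h to 14 h.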

Compound 4, half-life: 2.8 h
Compound 4: middle estimate off by 1.8-fold (0.25 log units), on the high side; the measured number falls inside the stated range.
By their numbers in this assay, from the lowest: compound 2; then compounds 4, 1 and 3 (each within the scatter of the next, the first and the last beyond it).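

On the sulfonyl sulfur, swapping a ring of carbon only for one holding a nitrogen is not neutral: this assay shows a 2.8-fold lower number from compound 3 to compound 4 (0.44 log units; beyond the scatter). Pyrrolidin-1-yl stays far from 4-methylphenyl, with an 11-fold higher number from compound 2 to compound 4 (1.03 log units; beyond the scatter), and close to 4-fluorophenyl, with a 1.6-fold lower number from compound 1 to compound 4 (0.21 log units; within the scatter). Nothing available explains the step from cyclopentyl to pyrrolidin-1-yl. Open, as far as these compounds go, is whether morpholin-4-yl or an open-chain dimethylamino group on the sulfonyl sulfur would track pyrrolidin-1-yl or cyclopentyl.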